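The source may report more compounds than this note shows. Statements on the series, on what has been measured and on what is new or still open speak of the compounds shown alone.

Measured so far in a functional assay (aorta) with Rattus norvegicus as the target; on this read-out lower numbers stand for an effect already at smaller amounts and higher numbers for an effect only at larger amounts of compound: compound 1 `CC1(C)CC(NC(=O)Nc2ccccc2)c2cc(Cl)ccc2O1` gives 7800 nM. Compound 2 `CC1(C)CC(NC(=O)Nc2ccccc2)c2cc(Br)ccc2O1` gives 2300 nM. Compound 3 `CC1(C)CC(NC(=O)Nc2ccc(Cl)cc2)c2cc(Cl)ccc2O1` gives only a limit of the assay, > 300000 nM.

Compound 2 differs from compound 1 by bromo in place of chloro on an aromatic carbon, and this change brought a 3.4-fold lower number from compound 1 to compound 2 (0.53 log units; beyond the scatter). Compound 3 differs from compound 1 by chloro in place of hydrogen on an aromatic carbon, and this brought an at least 38-fold higher number from compound 1 to compound 3 (1.58 log units; beyond the scatter), so that compound 3 sits at the limit of > 300000 nM in this assay, at which 1 of the 3 values shown sits, where no number is read.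

Compound 4 `CC1(C)CC(NC(=O)Nc2ccc(Cl)cc2)c2cc(Br)ccc2O1` is not yet measured. Within the data shown here, it differs from compound 3 by bromo in place of chloro on an aromatic carbon, which is the same change as the one from compound 1 to compound 2, made at the same place. On that basis the step from compound 3 to compound 4 is expected to be of about the size seen from compound 1 to compound 2, which is an estimate of a step that the limit leaves unreadable from compound 3 to compound 4 beside a 3.4-fold lower number from compound 1 to compound 2 (0.53 log units; beyond the scatter). Since compound 3 gives only a limit, compound 4 is expected to stay near or beyond that limit. Compound 4 is therefore estimated at 400000 nM, between 90000 nM and 2000000 nM.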

Compound 4, half-maximal effective concentration: > 300000 nM
Compound 4 was reported as a limit; the forecaster's own chance of this, stated with the estimate: 70%; the middle value lies beyond the limit too.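

In this assay compound 4 gives > 300000 nM, which is a limit of the assay and not a number. Chloro in place of hydrogen brought an at least 130-fold higher number from compound 2 to compound 4 (2.11 log units; beyond the scatter), so on the core carrying bromo the number rose sharply, as it did on the core carrying chloro, and the change carried over in direction on the two cores: the same change on two cores in this assay, an at least 38-fold higher number (1.58 log units; beyond the scatter) from compound 1 to compound 3 and an at least 130-fold higher number (2.11 log units; beyond the scatter) from compound 2 to compound 4; the limit leaves it open whether they differ. The true size of the rise on either core is not shown, and the step from compound 3 to compound 4 cannot be read, so it remains unknown whether bromo in place of chloro still lowers the number once the second chloro is present.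

The compounds shown leave open whether the rise belongs to chloro itself or would also come with another group in its place, such as fluoro or methoxy. They also leave open what an amine or a carboxylic acid would do in place of the bromo.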